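The source may hold more compounds than are shown below. What is called first, only, known or untested is meant among the compounds shown, and "the series" means these compounds.

Working notes on the series.

Of the compounds shown here, three of the shared core have been measured in a physicochemical assay for lipophilicity; on this read-out lower numbers stand for lower lipophilicity and higher numbers for higher lipophilicity. Compound 1 `CN1CCN(CCCS(=O)(=O)c2ccc3nc(NC(=O)NC(=O)c4cccc(-n5cccn5)c4Cl)sc3c2)CC1` gives 1.6. Compound 2 `CCN(CC)CCCS(=O)(=O)c1ccc2nc(NC(=O)NC(=O)c3cc(-n4cccn4)ccc3Cl)sc2c1` gives 2.1, and compound 3 `CS(=O)(=O)c1ccc2sc(NC(=O)NC(=O)c3ccccc3Cl)nc2c1` gives 2.8. Compound 1 stands lowest of the three numbers; its nearest neighbour is compound 2, which lies higher by a margin beyond the scatter, and compound 3 lies further above, also beyond the scatter. No pair among these three differs in a single place, so no step of this assay has yet been read off directly.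

Compound 4 `CN1CCN(CCCS(=O)(=O)c2ccc3nc(NC(=O)NC(=O)c4ccccc4Cl)sc3c2)CC1` has not been measured in this assay. It differs from compound 1 by hydrogen in place of 1H-pyrazol-1-yl on an aromatic carbon, ortho to a chloro group and meta to a large group. The removal takes away a five-membered aromatic ring with two heteroatoms and two hydrogen-bond acceptors while the rest of compound 1 is kept. In the absence of any measured single-place step in this assay, the expectation is a small downward move, of a size that is expected to stay within the scatter, a number 0.20 log units lower from compound 1 to compound 4 (within the scatter). For compound 4 the estimate in this assay is 1.4, with a range from 0.9 to 1.9.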

Compound 4, distribution coefficient: 1.8
The estimate for compound 4 lay 0.40 log units below the measured number; the range from low to high includes it.
By their numbers in this assay, from the lowest: compounds 1, 4 and 2 (each within the scatter of the next, the first and the last beyond it); then compound 3.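

The first step read directly in this assay belongs to this position: with hydrogen in place of 1H-pyrazol-1-yl on an aromatic carbon, the read-out shows a number 0.20 log units higher from compound 1 to compound 4 (within the scatter) while the rest of the structure is kept. Among these compounds, on the side chain of compound 1, taking away one five-membered aromatic ring with 5 heavy atoms and 2 hydrogen-bond acceptors, ortho to a chloro group and meta to a large group, therefore leaves the number within the scatter, something the earlier compounds could not show because none of them differed in a single place. No measurement at hand bears on why this change gives a step of this size.

Among the compounds shown here, whether a carboxylic acid or a methoxy group on the same aromatic carbon would give a step beyond the scatter stays open, since hydrogen and 1H-pyrazol-1-yl are the only two groups compared there. Also open, as far as these compounds go, is whether the same replacement would give a step of similar size with a longer chain or a morpholine ring at the far end of the sulfonyl side chain.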